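Swapping iodo for methyl on a weakly cytotoxic urea

The compounds below may be only part of what the source reports. "The series", "measured", "known", "first", "only" and "open" are said of these compounds alone.

Compound 1, `O=C(Nc1ccc(F)cc1)N[C@H]1CC[C@H](Oc2ccc(F)cc2)CC1`: 20000 nM
Compound 2, `CSc1ccccc1NC(=O)N[C@H]1CC[C@H](Oc2ccc(F)cc2)CC1`: > 20000 nM (a limit)
Compound 3, `O=C(Nc1ccccc1I)N[C@H]1CC[C@H](Oc2ccc(F)cc2)CC1`: > 20000 nM (a limit)

In a functional assay on CRL2813 cells (Homo sapiens) for cytotoxicity, read by sulforhodamine B assay, with a stated time of 5 days (on this read-out higher numbers stand for weaker inhibition and lower numbers for stronger inhibition), compound 1 gives 20000 nM. For compound 2 the assay reports only a limit, > 20000 nM. For compound 3 the assay likewise reports only a limit, > 20000 nM. Two of the three values shown thus sit at the limit of > 20000 nM in this assay, at which 2 of the 3 values shown sit. Compound 3 therefore stands among the weakest of the three on the numbers shown, though the limit leaves open how weak.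

Compound 4, `Cc1ccccc1NC(=O)N[C@H]1CC[C@H](Oc2ccc(F)cc2)CC1`, differs from compound 3 by methyl in place of iodo on an aromatic carbon. Within the data shown here, three measured steps touch this part of the shared core. The step of a number no lower from compound 1 to compound 3 (the limit leaves the size open) and the step of a number no lower from compound 1 to compound 2 (the limit leaves the size open) both run toward the limit, and the step that the two limits leave unreadable from compound 2 to compound 3 runs between two limits. None of them yields a readable size; all they show is that every replacement made so far on the aromatic ring of carbon only has left the compound at or past the edge of what this assay can measure.

On that basis compound 4 is expected to give about 20000 nM in this assay, between 8000 nM and 50000 nM. The estimated step of a number no higher from compound 3 to compound 4 (the limit leaves the size open) is expected to be none beyond the scatter, with a real chance that only a limit is reported again.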

Compound 4, half-maximal inhibitory concentration: > 20000 nM
Compound 4: a limit, no number (the forecaster's own chance of this, stated with the estimate: 65%); the middle value lies on the limit itself.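

Methyl now joins iodo and methylsulfanyl as a third group at this place on the ring, and the readout does not separate it from them. In this assay compound 4 gives > 20000 nM, which is a limit and not a number. The steps among compounds 2, 3 and 4 therefore cannot be read, and the only direction available is a number no lower from compound 1 to compound 4 (the limit leaves the size open). The three compounds with a group at this place now sit at one shared edge of the measurement: the limit of > 20000 nM in this assay, at which 3 of the 4 values shown sit.

Going by these compounds, how far compounds 2, 3 and 4 lie past that limit, and whether they differ from one another, stays open. Also open, on these data alone, is whether an amine or a carboxylic acid at this place on the ring would bring the value back to a measurable number.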